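The source may report more compounds than this note shows. Statements on the series, on what has been measured and on what is new or still open speak of the compounds shown alone.

In a functional assay (aorta) with Oryctolagus cuniculus as the target (on this read-out lower numbers stand for tighter binding and higher numbers for weaker binding), compound 1 `COc1ccc(C(c2ccc(OC)cc2)C2CCN(CCCOc3ccc(C(C)=O)cc3OC)CC2)cc1` gives 10 nM, compound 2 `COc1cc(C(C)=O)ccc1OCCCN1CCC(C(c2ccc(F)cc2)C2CCCCC2)CC1` gives 5.01 nM, and compound 3 `CCc1ccc(OCCCN2CCC(C(c3ccc(F)cc3)c3ccc(F)cc3)CC2)c(OC)c1` gives 2.51 nM. Compound 3 carries the lowest of the three numbers; its gap to compound 2 lies within the scatter, while its gap to compound 1 lies beyond it. Compound 4 `Nc1ccc(OCCCN2CCC(C(c3ccc(F)cc3)c3ccc(F)cc3)CC2)cc1` has not yet been measured in this assay. It differs from compound 3 in one place: 4-aminophenyl in place of 4-ethyl-2-methoxyphenyl on an oxygen on a saturated carbon. Among the compounds with values here, no measured pair shows this change, so the expectation rests on compound 3 alone. The step of a 2.4-fold higher number from compound 3 to compound 4 (0.38 log units; beyond the scatter) is expected to be a moderate rise in the number, close to the edge of the scatter. Compound 4 is therefore estimated at 6 nM, with a range from 2 nM to 20 nM.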

Compound 4, dissociation constant: 31.6 nM
Compound 4: the middle estimate sits 5.3-fold (0.72 log units) below what was measured; measured number above the stated range.
By their numbers in this assay, from the lowest: compounds 3, 2 and 1 (each within the scatter of the next, the first and the last beyond it); then compound 4.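

In this assay, the change from 4-ethyl-2-methoxyphenyl to 4-aminophenyl on this oxygen gives a 13-fold higher number from compound 3 to compound 4 (1.10 log units; beyond the scatter), the first step read at this position. It shows that the number depends strongly on this aryl group, in a swap that brings in a hydrogen-bond donor and leaves fewer heavy atoms. Nothing available here bears on the reason for the rise. The step combines three differences: the ethyl and the methoxy leave, and the amine enters. Which of them carries the rise stays open, a question that 4-ethylphenyl or 4-amino-2-methoxyphenyl on the same oxygen would address.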